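Swapping the amide cap on a bis-indole nitrile core

This account rests on a few compounds, and the source may have more. Where it says the series, first, only, none or still open, it means among the compounds named here.

Of the compounds shown here, three sharing one core have been tested in a functional assay on HepG2 cells (Homo sapiens) for cytotoxicity, read by MTT assay, with a stated time of 72 h; on this read-out lower numbers stand for stronger inhibition and higher numbers for weaker inhibition. Compound 1 `CN1[C@@H]2c3[nH]c4ccccc4c3C[C@H]1[C@H](C#N)N1[C@@H](CN3C(=O)c4ccccc4C3=O)c3[nH]c4ccccc4c3C[C@@H]21` gives 20 nM. Compound 2 `COc1ccc(C(=O)NC[C@H]2c3[nH]c4ccccc4c3C[C@H]3[C@H]4c5[nH]c6ccccc6c5C[C@@H]([C@H](C#N)N23)N4C)cc1` gives 310 nM, and compound 3 `CN1[C@@H]2c3[nH]c4ccccc4c3C[C@H]1[C@H](C#N)N1[C@@H](CNC(=O)c3cc4ccccc4s3)c3[nH]c4ccccc4c3C[C@@H]21` gives 300 nM. Compound 2 therefore stands with the highest number of the three: compound 1 lies far away, as a 16-fold higher number from compound 1 to compound 2 (1.19 log units; beyond the scatter) shows, while compound 3 sits within the usual scatter, as a 1.0-fold lower number from compound 2 to compound 3 (0.01 log units; within the scatter) shows.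

Compound 4 `CN1[C@@H]2c3[nH]c4ccccc4c3C[C@H]1[C@H](C#N)N1[C@@H](CNC(=O)/C=C/c3ccccc3)c3[nH]c4ccccc4c3C[C@@H]21` is formed from compound 2 by a single exchange: 2-phenylethenyl in place of 4-methoxyphenyl on a carbonyl carbon. Among the compounds with values here, the step that bears most directly on this is the one from compound 2 to compound 3, which also swapped the group on the carbonyl carbon of the amide and produced a 1.0-fold lower number from compound 2 to compound 3 (0.01 log units; within the scatter). The large steps of a 16-fold higher number from compound 1 to compound 2 (1.19 log units; beyond the scatter) and a 15-fold higher number from compound 1 to compound 3 (1.18 log units; beyond the scatter) arose from a different kind of exchange, one that altered more than the amide cap, so they give little guidance here. On this basis compound 4 is expected to move by no more than a 1.0-fold lower number from compound 2 to compound 4 (0.01 log units; within the scatter), staying close to compound 2. The estimated value for compound 4 in this assay is 300 nM, with a range from 100 nM to 900 nM.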

Compound 4, half-maximal inhibitory concentration: 470 nM
Estimate against measurement, compound 4: 1.6-fold (0.19 log units) below; low and high end bracket the measured number.
By their numbers in this assay, from the lowest: compound 1; then compounds 3, 2 and 4 (each within the scatter of the next).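

Replacing 4-methoxyphenyl with 2-phenylethenyl on the carbonyl carbon removes the oxygen of the cap and adds a double bond outside the aromatic ring, yet in this assay it gives a 1.5-fold higher number from compound 2 to compound 4 (0.18 log units; within the scatter). Within the data shown here, exchanging 1-benzothiophen-2-yl for the same group gives a 1.6-fold higher number from compound 3 to compound 4 (0.19 log units; within the scatter), so three differently built aromatic caps now stand together at this position, where the earlier compounds offered only a single pair. Compound 1 goes against this flat picture, with a 24-fold higher number from compound 1 to compound 4 (1.37 log units; beyond the scatter), but no measurement is available that explains either the flat response among the three amides or this large gap.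

The caps shown all carry an aromatic ring, so it remains open whether a simple methyl group, a longer saturated chain, or a cap ending in an amine or a carboxylic acid would stay in the same range. It is also unresolved which feature of the group in compound 1, with its five-membered non-aromatic ring, accounts for its separation from the other three compounds.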